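Swapping a Fluoropyridine for a Trifluoromethylphenyl Ring

The source may report more compounds than this note shows. Statements on the series, on what has been measured and on what is new or still open speak of the compounds shown alone.

Compound 1 `Cc1cc(NC(=O)Cn2nnc(-c3cccnc3)n2)n(C2CCCCC2)n1`: 96%
Compound 2 `Cc1cc(NC(=O)Cn2nnc(-c3ccnc(F)c3)n2)n(C2CCCCC2)n1`: 95%
Compound 3 `Cc1cc(NC(=O)Cn2nnc(-c3cccc(F)n3)n2)n(C2CCCCC2)n1`: > 83%

In an assay on HEK293 cells for activation of Kir3.1/Kir3.2 (Homo sapiens), read by thallium flux (a higher number here means a larger maximal response, a lower number a smaller maximal response), compound 1 gives 96% and compound 2 gives 95%. The move between them is a number 1 percentage points lower from compound 1 to compound 2 (within the scatter). For compound 3 this assay reports only a limit, > 83%, not a number (the limit of > 83% in this assay, at which 1 of the 3 values shown sits). Because of that limit, the moves a step that the limit leaves unreadable from compound 1 to compound 3 and a step that the limit leaves unreadable from compound 2 to compound 3 cannot be sized.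

Compound 4 `Cc1cc(NC(=O)Cn2nnc(-c3ccc(C(F)(F)F)cc3)n2)n(C2CCCCC2)n1` differs from compound 3 in one place: 4-(trifluoromethyl)phenyl in place of 6-fluoropyridin-2-yl on an aromatic carbon. Going by the values given here, no measured step puts a ring of carbon only in this position, and no readable step leads into compound 3 itself. Among the compounds with values here, the only readable step, between compound 1 and compound 2, stayed within the scatter, and both full numbers sit near the top of the range.

Compound 4 is therefore expected to reach about 90% in this assay, with a likely range from 70% to 105%. The expected step is a step that the limit leaves unreadable from compound 3 to compound 4.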

Compound 4, largest response reached (Emax), in percent of the reference or control that the assay uses: 94%
The estimate for compound 4 lay 4 percentage points below the measured number; the range from low to high includes it.
By their numbers in this assay, from the lowest: compounds 4, 2 and 1 (each within the scatter of the next).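

Swapping the pyridine for a ring of carbon only leaves the response in this assay unchanged within the scatter, with a number 1 percentage points lower from compound 2 to compound 4 (within the scatter) and a number 2 percentage points lower from compound 1 to compound 4 (within the scatter). Among compounds 1, 2 and 4, then, a nitrogen in this ring is not needed for a response of this size, and the ring can carry a trifluoromethyl group. Steps to or from compound 3 cannot be read because compound 3 has a limit rather than a number: the limit of > 83% in this assay, at which 1 of the 4 values shown sits.

Every group shown at this position is a six-membered aromatic ring, so it remains open how a saturated ring such as piperidine, or a phenyl ring bearing a carboxylic acid or an amine, would behave. The largest response also leaves open how much of each compound is needed to reach it.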